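A few compounds are considered here, and "the series" means these few. Any claim that something is new, unique, unknown or untested is made for them only; others in the source may bear on it.

Only a thin set of data frames this series in a functional assay on HepG2 cells (Homo sapiens) for cytotoxicity, read by MTT assay, with a stated time of 72 h; a lower number here means a stronger inhibitor, a higher number a weaker inhibitor. Compound 1 `CNC(=O)c1cc(Oc2ccc(C(=O)/C=C/c3ccc([N+](=O)[O-])cc3)cc2)ccn1` is the starting point, yet it offers no anchor: its entry in this assay reads "not determined" (no result reported), so it has no position on the scale. Going by the values given here, the only number comes from compound 2 `CNC(=O)c1cc(Oc2ccc(/C=C/C(=O)c3ccc(Br)cc3)cc2)ccn1`, which gives 22000 nM.

The step of interest leads from compound 1 to compound 3 `CNC(=O)c1cc(Oc2ccc(C(=O)/C=C/c3ccc(Cl)cc3Cl)cc2)ccn1`, and it is a change in one place: 2,4-dichlorophenyl in place of 4-nitrophenyl on a double-bonded chain carbon bound to a double-bonded chain carbon. Here 2,4-dichlorophenyl replaces 4-nitrophenyl on a double-bonded chain carbon bound to a double-bonded chain carbon, while the rest of compound 1 stays unchanged.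

Among the compounds with values here, no measured pair shows what such a replacement does, and without a number for compound 1 the step cannot be sized from the data. The expectation is therefore a step no larger than the scatter in this assay, with no direction favoured, and the closest guide is compound 2 at 22000 nM. For compound 3 the expected value is about 15000 nM, with an estimated range from 4000 nM to 50000 nM.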

Compound 3, half-maximal inhibitory concentration: 11700 nM
Estimate against measurement, compound 3: 1.3-fold (0.11 log units) above; the measured number falls inside the stated range.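

Going by these compounds alone, compound 1 has no number to set against compound 3, so no step between the two can be read from these results. No supporting evidence bears on this result. Going by these compounds, what replacing 4-nitrophenyl with 2,4-dichlorophenyl does to cytotoxicity on the shared core, in size or direction, remains open.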